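Halogen swap on the allyloxy core: bromo to chloro

The compounds below may be only part of what the source reports. "The series", "measured", "known", "first", "only" and "open" are said of these compounds alone.

Compound 1 `C=CCOc1ccc(Br)cc1C(=O)c1cccnc1` gives 78000 nM in a functional assay on Hep cells (Homo sapiens) for cytotoxicity, read by sulforhodamine B assay, with a stated time of 48 h (a higher number here means a weaker inhibitor, a lower number a stronger inhibitor), the second highest of the three numbers recorded. Compound 2 `O=C(c1cccnc1)c1ccc(Br)cc1O` lies nearest with 85000 nM, within the scatter of compound 1. Within the data shown here, compound 3 `O=C(c1cccnc1)c1cc(Br)ccc1O` is furthest with 29000 nM; the one measured step, a 2.7-fold lower number from compound 1 to compound 3 (0.43 log units; beyond the scatter), hydrogen in place of allyl on an oxygen on an aromatic ring, is modest. Compound 4 `C=CCOc1ccc(Cl)cc1C(=O)c1cccnc1` differs from compound 1 by chloro in place of bromo on an aromatic carbon. Among the measured compounds shown here, no measured step exchanges one halogen for another, so none bears on this change; a step within the scatter is expected, in no set direction. Compound 4 is therefore estimated at 78000 nM, between 35000 nM and 170000 nM. The expected step is no change at the digits printed from compound 1 to compound 4 (within the scatter).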

Compound 4, half-maximal inhibitory concentration: > 100000 nM
Compound 4 ended at the assay's limit; the forecaster's own chance of this, stated with the estimate: 15%; at least 1.2-fold (0.10 log units) between middle value and limit.
By their numbers in this assay, from the lowest: compound 3; then compounds 1 and 2 (each within the scatter of the next). At a limit, above all of these: compound 4.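

In this assay, chloro in place of bromo on this aromatic carbon, para to the allyloxy group, gives an at least 1.2-fold higher number from compound 1 to compound 4 (0.10 log units; that floor lies within the scatter). That floor does not establish a real loss, but chloro at this position brings no lower number than bromo. Compound 4 stands at a limit of the assay, not at a measured number: the limit of > 100000 nM in this assay, at which 1 of the 4 values shown sits.

As far as these compounds go, how the halogen exchange reads on the cores of compound 2 and compound 3 stays open. So does whether an amine or a carboxylic acid at this position would lower the number in this assay.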